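Pyrrolidinyl for dimethylamino on the thioalkyl chain

The source may hold more compounds than are shown below. What is called first, only, known or untested is meant among the compounds shown, and "the series" means these compounds.

Going by the values given here, compound 1 `CN(C)CCCCCSC1=Nc2ccccc2C(CC(=O)NCc2ccccc2)N1c1ccccc1` is the one member of the series with a number: in an assay on cells for inhibition of Voltage-dependent T-type calcium channel subunit alpha-1I (Homo sapiens), read by patch clamp, tested at 10 uM (on this read-out lower numbers stand for less inhibition and higher numbers for more inhibition at the one concentration tested (going by the name of the read-out)), compound 1 gives 76%. Among the compounds with values here, its fluorinated relative, compound 2 `CN(C)CCCCCSC1=Nc2ccccc2C(CC(=O)NCc2ccc(F)cc2)N1c1ccccc1`, is reported in this assay only as "not active" (no number reported) with no figure attached, so no step between the two can be sized. Compound 3 `O=C(CC1c2ccccc2N=C(SCCCCCN2CCCC2)N1c1ccccc1)NCc1ccccc1` carries the change pyrrolidin-1-yl in place of dimethylamino on a saturated chain carbon, five bonds along the chain from a sulfur and awaits measurement in this assay. Within the data shown here, with no measured step of this kind available, the expected change from compound 1 to compound 3 is a number 1 percentage points lower from compound 1 to compound 3 (within the scatter), no more than the scatter. For compound 3 the estimate in this assay is 75%, ranging from 55% to 90%.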

Compound 3, a percentage reported as inhibition, at one concentration (the size of the read-out at that concentration, not a potency): 78.3%
Beside the measured number, compound 3's estimate is 3.3 percentage points below it, within the range that was stated.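

In this assay, pyrrolidin-1-yl in place of dimethylamino on a saturated chain carbon, five bonds along the chain from a sulfur, gives a number 2.3 percentage points higher from compound 1 to compound 3 (within the scatter). Going by these compounds alone, this is the first sized step, and it shows that this position accepts a five-membered non-aromatic ring in place of the open dimethylamino group without a change beyond the scatter. Nothing available explains this result.

Open, as far as these compounds go, is whether morpholin-4-yl or piperidin-1-yl at the same place would read alike, and whether a shorter chain would keep the inhibition. Also open, from the compounds shown here alone, is whether pyrrolidin-1-yl would give a number when paired with the fluorinated amide of compound 2.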